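Fluoro to Methyl: A Small Change, Same Expected Potency

This account rests on a few compounds, and the source may have more. Where it says the series, first, only, none or still open, it means among the compounds named here.

Compound 1 `N#C[Se]c1ccc(NC(=O)Oc2ccc(F)cc2)cc1` was tested in a functional assay on PC-3 cells (Homo sapiens) for cytotoxicity, read by MTT assay, with a stated time of 72 h (a lower number here means a stronger inhibitor of growth, a higher number a weaker inhibitor of growth), where compound 1 gives 40400 nM. Two related compounds were measured alongside it. Compound 2 `O=C(Nc1ccc([Se][Se]c2ccc(NC(=O)OCc3ccc([N+](=O)[O-])cc3)cc2)cc1)OCc1ccc([N+](=O)[O-])cc1` gives 27100 nM, and compound 3 `O=C(Nc1ccc([Se][Se]c2ccc(NC(=O)Oc3ccc(F)cc3)cc2)cc1)Oc1ccc(F)cc1` gives 31300 nM. Compound 1 has the highest of these three numbers, yet its gap to compound 3 and its gap to compound 2 both lie within the usual scatter of repeated measurements, so the three cannot be told apart on these data.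

Compound 4 `Cc1ccc(OC(=O)Nc2ccc([Se]C#N)cc2)cc1` differs from compound 1 in one place: methyl in place of fluoro on an aromatic carbon. Neither group carries a charge, a donor or an acceptor, and the exchange leaves the rest of the structure untouched. No measured pair among these compounds shows what such a swap does to the number, so no direction can be read from the data. The step of a 1.0-fold lower number from compound 1 to compound 4 (0.00 log units; within the scatter) is therefore expected to stay within the scatter. The estimate for compound 4 is 40000 nM, expected to fall between 18000 nM and 90000 nM.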

Compound 4, concentration for total growth inhibition: 32300 nM
Compound 4: middle estimate off by 1.2-fold (0.09 log units), on the high side, within the range that was stated.
By their numbers in this assay, from the lowest: compounds 2, 3, 4 and 1 (each within the scatter of the next).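

This exchange now has a measured pair behind it. In this assay methyl in place of fluoro on an aromatic carbon, para to a large group, gives a 1.3-fold lower number from compound 1 to compound 4 (0.10 log units; within the scatter) and so compound 1 and compound 4 cannot be told apart. Among these compounds, the earlier compounds held no pair differing in one place, so this is the first direct sign that either of these two groups can sit here without a change beyond the scatter, and nothing available explains the result.

From the compounds shown here alone, what stays open is whether a group of another kind at this place, such as an amine, a carboxylic acid or a longer chain, would move the number beyond the scatter. Also open, going by these compounds, is whether the same exchange on compound 3 would give a similarly small step.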